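This account rests on a few compounds, and the source may have more. Where it says the series, first, only, none or still open, it means among the compounds named here.

Compound 1, `COC(=O)/C=C/c1cccc(N(Cc2ccc(/C=C/c3cc(C(F)(F)F)cc(C(F)(F)F)c3)cc2)C(=O)C2CCCCC2)c1`, and compound 2, `COC(=O)/C=C/c1cccc(N(Cc2ccc(/C=C/c3cc(C(F)(F)F)cc(C(F)(F)F)c3)cc2)C(=O)C(C)C)c1`, share one core and differ only at the acyl group. In an assay on isolated protein with Bile acid receptor (Homo sapiens) as the target (on this read-out higher numbers stand for an effect only at larger amounts of compound and lower numbers for an effect already at smaller amounts), compound 1 gives 1470 nM, while compound 2 gives 1950 nM. The change between them is isopropyl in place of cyclohexyl on a carbonyl carbon, and it produced a 1.3-fold higher number from compound 1 to compound 2 (0.12 log units; within the scatter), a step that does not rise above the usual scatter of this assay.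

Compound 3, `COC(=O)/C=C/c1cccc(N(Cc2ccc(/C=C/c3cccc(F)c3)cc2)C(=O)C2CCCCC2)c1`, carries a different core; how its core differs from that of compound 1 is not broken down here. In this assay compound 3 gives 86 nM, the lowest of the three numbers, and its distance from compound 1 and from compound 2 lies well beyond the scatter, so compound 3 counts as the most potent of the measured set.

Compound 4, `COC(=O)/C=C/c1cccc(N(Cc2ccc(/C=C/c3cccc(F)c3)cc2)C(=O)C(C)C)c1`, stands to compound 3 as compound 2 stands to compound 1: the change is isopropyl in place of cyclohexyl on a carbonyl carbon, the same change as before, at the same kind of place. On the core of compound 1 this change left the number essentially unmoved, so the expectation is that compound 4 tracks compound 3 closely, with a step of about a 1.3-fold higher number from compound 3 to compound 4 (0.11 log units; within the scatter) expected in this assay, because the earlier instance of the change gave a 1.3-fold higher number from compound 1 to compound 2 (0.12 log units; within the scatter). Compound 4 is therefore estimated at 110 nM in this assay. The estimate for compound 4 is expected to fall between 50 nM and 250 nM.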

Compound 4, half-maximal effective concentration: 71 nM
For compound 4 the middle estimate is 1.5-fold (0.19 log units) above the measured one; low and high end bracket the measured number.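

In this assay, putting isopropyl in place of cyclohexyl on the carbonyl carbon gives a 1.2-fold lower number from compound 3 to compound 4 (0.08 log units; within the scatter) and so stays inside the usual scatter, just as it did on the core of compound 1. Within that scatter, the change carries from one core to the other, and the two instances cannot be told apart: the same change on two cores in this assay, a 1.3-fold higher number (0.12 log units; within the scatter) from compound 1 to compound 2 and a 1.2-fold lower number (0.08 log units; within the scatter) from compound 3 to compound 4, 1.6-fold (0.21 log units) apart, within the scatter of two such steps

This shows only that cyclohexylcarbonyl and isopropylcarbonyl could not be distinguished in this read-out on these two cores, and it rests on just two pairs, so it gives no assurance for any further core and no explanation of why the exchange leaves the number where it is.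

The compounds shown leave open whether other acyl groups, such as a tert-butylcarbonyl, a benzoyl or a longer chain ending in an amine, would also leave the number within the scatter on these cores. They also leave open whether the isopropyl and cyclohexyl exchange would stay this quiet with a carboxylic acid in place of the methyl ester, or in any read-out other than this binding measurement on isolated protein.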